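The compounds below may be only part of what the source reports. "The series", "measured", "known", "first", "only" and "open" are said of these compounds alone.

Three compounds have so far been measured in a functional assay on MDA-MB-231 cells (Homo sapiens) for inhibition, read by MTT assay, with a stated time of 72 h; on this read-out higher numbers stand for weaker inhibition and lower numbers for stronger inhibition:

compound 1, `CCc1cccc(NC(=O)CSc2nc(Nc3ccccc3)c3ccccc3n2)c1`: 12400 nM
compound 2, `O=C(CSc1nc(Nc2ccccc2)c2ccccc2n1)Nc1ccc(F)cc1`: 34100 nM
compound 3, `O=C(CSc1nc(Nc2ccccc2)c2ccccc2n1)Nc1ccc(Cl)cc1`: 17200 nM

Compound 3 gives the second highest of the three numbers. Its nearest neighbour is compound 1, and the step of a 1.4-fold higher number from compound 1 to compound 3 (0.14 log units; within the scatter) lies within the scatter; its furthest is compound 2, and the step of a 2.0-fold lower number from compound 2 to compound 3 (0.30 log units; within the scatter) also lies within the scatter. All three compounds share the same core and differ only in the aryl group on the amide-type nitrogen.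

Compound 4, `O=C(CSc1nc(Nc2ccccc2)c2ccccc2n1)Nc1ccc(Br)cc1`, is the next member of this set. The change from compound 3 is bromo in place of chloro on an aromatic carbon. For the measured compounds named here, the one measured step that bears directly on it is the exchange of one halogen for another at the same place, a 2.0-fold lower number from compound 2 to compound 3 (0.30 log units; within the scatter), which did not reach beyond the scatter. The other steps, a 2.8-fold higher number from compound 1 to compound 2 (0.44 log units; beyond the scatter) and a 1.4-fold higher number from compound 1 to compound 3 (0.14 log units; within the scatter), swap a whole aryl group and so speak less directly to a halogen exchange. On this basis the step of a 1.2-fold lower number from compound 3 to compound 4 (0.09 log units; within the scatter) is expected to stay within the scatter, with at most a slight lean toward a lower number. Compound 4 is therefore estimated at 14000 nM, with a range from 7000 nM to 30000 nM.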

Compound 4, half-maximal inhibitory concentration: 11500 nM
Compound 4: middle estimate off by 1.2-fold (0.09 log units), on the high side, and the stated range covers the measured number.
By their numbers in this assay, from the lowest: compounds 4, 1, 3 and 2 (each within the scatter of the next, the first and the last beyond it).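

In this assay, the exchange of chloro for bromo on the aromatic carbon, para to a large group, leaves the two halogens indistinguishable (a 1.5-fold lower number from compound 3 to compound 4 (0.17 log units; within the scatter)). Fluoro and bromo at this same place, however, give the first halogen exchange here that clears the scatter (a 3.0-fold lower number from compound 2 to compound 4 (0.47 log units; beyond the scatter)), a separation the fluoro-to-chloro step had not reached, while 4-bromophenyl and 3-ethylphenyl on the amide-type nitrogen cannot be told apart (a 1.1-fold lower number from compound 1 to compound 4 (0.03 log units; within the scatter)). Nothing available explains why bromo reads differently from fluoro at this place while it does not from chloro.

The compounds shown leave open how an iodo, a methoxy, an amine or a carboxylic acid would read at this same place, and so whether the separation between fluoro and bromo extends to any group beyond the halogens. They also leave open whether this separation between fluoro and bromo would hold on a different core, as all of these compounds share a single one and a single cell line read-out.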